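Trifluoromethoxy in place of trifluoromethyl: a clearance estimate

This account rests on a few compounds, and the source may have more. Where it says the series, first, only, none or still open, it means among the compounds named here.

Of the compounds shown here, three on one shared core have numbers so far in an ADME assay on the whole organism (strain Sprague-Dawley) for pharmacokinetics, with Rattus norvegicus as the target, using cassette dosing (on this read-out lower numbers stand for slow clearance and higher numbers for fast clearance), for this series. Compound 1 (`O[C@]1(Cc2cc(-c3cn[nH]c3)on2)CC[C@H](Cc2ccc(Cl)cc2)CC1`) gives 11.7 mL/min/kg in this read-out. Compound 2 (`O[C@]1(Cc2cc(-c3cn[nH]c3)on2)CC[C@H](Cc2ccc(F)cc2)CC1`) gives 30 mL/min/kg in the same read-out. Compound 3 (`O[C@]1(Cc2cc(-c3cn[nH]c3)on2)CC[C@H](Cc2ccc(C(F)(F)F)cc2)CC1`) gives 4 mL/min/kg and is the lowest of the three, with both of its gaps beyond the scatter.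

Compound 4 (`O[C@]1(Cc2cc(-c3cn[nH]c3)on2)CC[C@H](Cc2ccc(OC(F)(F)F)cc2)CC1`) has trifluoromethoxy in place of trifluoromethyl on an aromatic carbon, para to a large group (trifluoromethoxy in place of trifluoromethyl on an aromatic carbon).

Going by the values given here, no measured step contains trifluoromethoxy, so the evidence is indirect. Three exchanges at this place bear on it. Fluoro in place of chloro gave a 2.6-fold higher number from compound 1 to compound 2 (0.41 log units; beyond the scatter) and trifluoromethyl in place of chloro gave a 2.9-fold lower number from compound 1 to compound 3 (0.47 log units; beyond the scatter) while trifluoromethyl in place of fluoro gave a 7.5-fold lower number from compound 2 to compound 3 (0.88 log units; beyond the scatter) as the largest of them. These show that the number responds to this place, but not how it responds to the new group. Among the compounds with values here, a slight upward lean is expected because compound 3 holds the lowest number at 4 mL/min/kg in this assay so far.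

The expected move is a 1.5-fold higher number from compound 3 to compound 4 (0.18 log units; within the scatter) and no step beyond the scatter is expected. The estimate for compound 4 is 6 mL/min/kg with an expected range of 2.5 mL/min/kg to 14 mL/min/kg as the working figures.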

Compound 4, clearance: 6.2 mL/min/kg
Estimate against measurement, compound 4: 1.0-fold (0.01 log units) below; the measured number falls inside the stated range.
By their numbers in this assay, from the lowest: compounds 3, 4 and 1 (each within the scatter of the next, the first and the last beyond it); then compound 2.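

In this assay, going by these compounds alone, trifluoromethoxy is the first group at this place, on an aromatic carbon para to a large group, that cannot be separated from trifluoromethyl, with a 1.6-fold higher number from compound 3 to compound 4 (0.19 log units; within the scatter). It also cannot be separated from chloro, with a 1.9-fold lower number from compound 1 to compound 4 (0.28 log units; within the scatter), but it stands clear of fluoro, with a 4.8-fold lower number from compound 2 to compound 4 (0.68 log units; beyond the scatter), so compound 4 lies within the scatter of both compound 1 and compound 3 even though those two are beyond the scatter of each other, and of the four compounds only compound 2 is beyond the scatter of all the others. No measurement shown gives a reason for this ordering of the groups.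

As far as these compounds go, the groups at this place are limited to halogens and fluorinated groups, so it remains open how methoxy without fluorine, a nitrile or an amine would read in this assay. The rest of the shared core is also the same in all four compounds, so it remains open whether the same separation among these groups would hold on a different core.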